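Hexyloxy in place of heptylamino: expected effect on potency

A few compounds are considered here, and "the series" means these few. Any claim that something is new, unique, unknown or untested is made for them only; others in the source may bear on it.

Of the compounds shown here, two have been measured in an assay on microsomes from liver for inhibition of sterol O-acyltransferase 1 (Rattus norvegicus); a higher number here means a weaker inhibitor, a lower number a stronger inhibitor. Compound 1 `O=C(O)CCCCCCCn1nc(-c2ccccc2)c(-c2ccccc2)cc1=O` carries a carboxylic acid chain on a ring nitrogen of a related core; in this assay compound 1 reaches only a limit, > 300000 nM, which is a limit of the assay and not a number. Going by the values given here, compound 2 `CCCCCCCNc1cc(-c2ccccc2)c(-c2ccccc2)nn1`, with a heptylamino group on the shared core, is the only compound with a numeric value: in this assay compound 2 gives 55000 nM. Among the compounds with values here, the other value shown is the limit of compound 1, noted as the limit of > 300000 nM in this assay, at which 1 of the 2 values shown sits, so no measured step is available.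

Compound 3 `CCCCCCOc1cc(-c2ccccc2)c(-c2ccccc2)nn1` differs from compound 2 in one place: hexyloxy in place of heptylamino on an aromatic carbon. Within the data shown here, no measured pair informs this change, so the expected step is small, at most a modest loss that may stay within the scatter; the estimated step is a 1.5-fold higher number from compound 2 to compound 3 (0.16 log units; within the scatter). Compound 3 is therefore expected to give about 80000 nM in this assay, with a plausible range from 30000 nM to 250000 nM.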

Compound 3, half-maximal inhibitory concentration: 72000 nM
Compound 3: the middle estimate sits 1.1-fold (0.05 log units) above what was measured; the range from low to high includes it.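

In this assay, hexyloxy in place of heptylamino on this aromatic carbon gives a 1.3-fold higher number from compound 2 to compound 3 (0.12 log units; within the scatter), so the two compounds cannot be told apart. Going by these compounds alone, the read-out at this position therefore does not depend on the hydrogen-bond donor of heptylamino, at least for this pair, which is a point the earlier compounds could not show. Compound 1 adds no comparison, as it differs from these compounds in more than one place and its value is a limit of the assay: the limit of > 300000 nM in this assay, at which 1 of the 3 values shown sits.

As far as these compounds go, the change swaps the linking atom and alters the chain in one step, so the separate share of each stays open; heptyloxy or hexylamino on the shared core would pull the two apart. Also open, from the compounds shown here alone, is how far the number in this assay follows chain length at this position, and whether a much longer chain, a tertiary amine or a terminal carboxylic acid on the chain would move it beyond the scatter on the shared core.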